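A few compounds are considered here, and "the series" means these few. Any claim that something is new, unique, unknown or untested is made for them only; others in the source may bear on it.

Compound 1, `CCCCCCCCCCCCCCCCCCOCC(COP(=O)(O)O[C@H](C)C[N+](C)(C)C)OC`, gives 10.1 ug/mL in a functional assay on cells (B-lymphoblastic leukemic cell line, Homo sapiens) for cytotoxicity, with a stated time of 24 h; a lower number here means a stronger inhibitor, a higher number a weaker inhibitor.
Compound 2, `CCCCCCCCCCCCCCCCCCOCC(COP(=O)(O)O[C@@H](C)C[N+](C)(C)C)OC`, gives 9.8 ug/mL in this assay.

On these numbers compound 2 stands beside compound 1, the two separated by a 1.0-fold lower number from compound 1 to compound 2 (0.01 log units; within the scatter). That step rests only on a stereochemical drawing, (the fact that one of compounds 1 and 2 is drawn with a defined configuration and the other without, at the place where they differ), and tests no change of connectivity. Compound 3, `CCCCCCCCCCCCCCCCCCOCC(COP(=O)(O)OC[C@@H](C)[N+](C)(C)C)OC`, differs from compound 2 by a group of 7 heavy atoms (6 carbon, 1 nitrogen; no ring) in place of a group of 7 heavy atoms (6 carbon, 1 nitrogen; no ring), on an oxygen. Within the data shown here, no measured step bears on such a rearrangement of the same atoms, so for compound 3 no shift beyond the scatter is expected in this assay. Compound 3 is therefore estimated at 10 ug/mL, between 5 ug/mL and 20 ug/mL. For compound 3 the expected step is a 1.0-fold higher number from compound 2 to compound 3 (0.01 log units; within the scatter).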

Compound 3, concentration for 50% inhibition: 9.9 ug/mL
Estimate against measurement, compound 3: 1.0-fold (0.00 log units) above; low and high end bracket the measured number.
By their numbers in this assay, from the lowest: compounds 2, 3 and 1 (each within the scatter of the next).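

In this assay, rejoining the same atoms within the group of 7 heavy atoms, on an oxygen whose other neighbour is phosphorus, gives a step within the scatter: a 1.0-fold higher number from compound 2 to compound 3 (0.00 log units; within the scatter). The comparison with the other stereo drawing reads the same: a 1.0-fold lower number from compound 1 to compound 3 (0.01 log units; within the scatter). So among these three compounds, connectivity within this group, and not only its drawn configuration, can differ without a step beyond the scatter, and nothing given here accounts for this result.

As far as these compounds go, whether a tertiary amine or a carboxylic acid in place of this group would keep the number remains open. So does the effect of a longer chain on the nitrogen.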